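Methoxy for chloro on the shared core of compound 2

This account rests on a few compounds, and the source may have more. Where it says the series, first, only, none or still open, it means among the compounds named here.

Measured so far:
compound 1 `CNc1ncc(C(N)=O)cn1`, > 10000 nM
compound 2 `CNc1cc(Cl)c(C(N)=O)cn1`, 639 nM
compound 3 `Cc1c(C(N)=O)c[n+]([O-])c2c1CCN2`, 7060 nM

In an assay on isolated protein for inhibition of Nicotinamide N-methyltransferase (Homo sapiens), read by luminescence, with a stated time of 20 min (on this read-out higher numbers stand for weaker inhibition and lower numbers for stronger inhibition), compound 1 gives only a limit, > 10000 nM, and no number. Compound 2 gives 639 nM in this assay, the lower of the two numbers shown; the nearest number, from compound 3 at 7060 nM, sits above it by a gap that lies beyond the usual scatter. Compound 4 `CNc1cc(OC)c(C(N)=O)cn1` differs from compound 2 in one place: methoxy in place of chloro on an aromatic carbon, ortho to the carbamoyl group and opposite the ring nitrogen. Within the data shown here, no step between measured compounds is given for this exchange, so the size of the step can only be expected. Compound 4 is estimated to give 1500 nM in this assay, within 400 nM to 6000 nM, which means an expected step of a 2.3-fold higher number from compound 2 to compound 4 (0.37 log units; beyond the scatter) toward a weaker number, of a size that may or may not pass beyond the scatter.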

Compound 4, half-maximal inhibitory concentration: > 10000 nM
Compound 4 gave a limit, no number; the forecaster's own chance of this, stated with the estimate: 10%; middle value at least 6.6-fold (0.82 log units) away from the limit.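

Methoxy in place of chloro on this aromatic carbon, ortho to the carbamoyl group and opposite the ring nitrogen, brings an at least 15-fold higher number from compound 2 to compound 4 (1.19 log units; beyond the scatter) in this assay, the first reading on this position, and it shows that the position does not tolerate every exchange. Compound 4 gives only a limit, > 10000 nM, and not a number, so the step has a floor and no measured size. Only compound 2 and compound 3 therefore give numbers, while the other two compounds stop at a single value: the limit of > 10000 nM in this assay, at which 2 of the 4 values shown sit.

This single exchange cannot show whether the loss belongs to methoxy alone or to any group other than chloro here. From the compounds shown here alone, it remains open whether fluoro, bromo, methyl or an amine on this carbon would keep a number close to that of compound 2.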